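The compounds below may be only part of what the source reports. "The series", "measured", "known", "first", "only" and "open" are said of these compounds alone.

Among the compounds with values here, compound 3 `Cn1cc(-c2cnc(N)c(Oc3ccc(C(=O)Nc4cc(Cl)ccn4)cc3)n2)cn1` carries the highest number of the three measured members in a functional assay on U-87MG ATCC cells for inhibition, with U-87 MG (Homo sapiens) as the target, read by MTT assay, with a stated time of 72 h; a higher number here means a weaker inhibitor, a lower number a stronger inhibitor: compound 3 gives 47900 nM, compound 2 `Cn1cc(-c2cnc(N)c(Oc3ccc(C(=O)Nc4ccc(Cl)cc4)cc3)n2)cn1` gives 35800 nM and compound 1 `Cn1cc(-c2cnc(N)c(Oc3ccc(C(=O)Nc4ccccc4)cc3)n2)cn1` gives 17700 nM. The step of a 1.3-fold higher number from compound 2 to compound 3 (0.13 log units; within the scatter) is within the scatter, whereas a 2.7-fold higher number from compound 1 to compound 3 (0.43 log units; beyond the scatter) and a 2.0-fold higher number from compound 1 to compound 2 (0.31 log units; beyond the scatter) lie beyond it. Compound 4 `Cn1cc(-c2cnc(N)c(Oc3ccc(C(=O)Nc4ncccc4Cl)cc3)n2)cn1` differs from compound 3 by 3-chloropyridin-2-yl in place of 4-chloropyridin-2-yl on an amide-type nitrogen. Within the data shown here, no measured step compares two chloropyridinyl groups with one another; the steps that touch this amide-type nitrogen exchange the whole ring and were modest or within the scatter. For this assay the expected step is therefore a 1.1-fold lower number from compound 3 to compound 4 (0.03 log units; within the scatter), within the scatter. Compound 4 is estimated at 45000 nM, range 18000 nM to 110000 nM.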

Compound 4, half-maximal inhibitory concentration: 37600 nM
Compound 4: middle estimate off by 1.2-fold (0.08 log units), on the high side, within the range that was stated.
By their numbers in this assay, from the lowest: compound 1; then compounds 2, 4 and 3 (each within the scatter of the next).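

3-Chloropyridin-2-yl in place of 4-chloropyridin-2-yl on the amide-type nitrogen gives a 1.3-fold lower number from compound 3 to compound 4 (0.11 log units; within the scatter) in this assay so the two chloropyridinyl groups are not separated here. 4-Chlorophenyl in place of the pyridine gives the same picture, with a 1.1-fold higher number from compound 2 to compound 4 (0.02 log units; within the scatter) while a 2.1-fold higher number from compound 1 to compound 4 (0.33 log units; beyond the scatter) places this third chlorinated ring, like the two before it, on the weaker side of the unsubstituted phenyl. No measurement at hand accounts for these steps.

Open, on these data alone, is whether plain pyridin-2-yl, without chloro, would sit with compound 1 or with the chlorinated members. Also open, as far as these compounds go, is how an amine or a carboxylic acid on this ring would read.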